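Swapping the dichlorophenyl for a fluorophenyl in compound 2

The source may hold more compounds than are shown below. What is called first, only, known or untested is meant among the compounds shown, and "the series" means these compounds.

In an assay on CHO-K1 cells for displacement of a labelled ligand from prostaglandin E2 receptor EP1 subtype (Homo sapiens) (a higher number here means a weaker inhibitor, a lower number a stronger inhibitor), compound 2 `Cc1cc(C(=O)O)nn1Cc1cc(Br)ccc1OCc1ccc(Cl)cc1Cl` gives 0.132 nM, the lower of the two numbers in hand. Within the data shown here, the only other measured compound, compound 1 `O=C(O)c1nn(Cc2cc(Br)ccc2OCc2ccccc2)cc1C(F)(F)F`, gives 2570 nM; the two differ in several places at once, so no single step can be read from them. Compound 3 `Cc1cc(C(=O)O)nn1Cc1cc(Br)ccc1OCc1ccc(F)cc1` changes compound 2 in one place: 4-fluorophenyl in place of 2,4-dichlorophenyl on a saturated chain carbon bound to an oxygen on an aromatic ring. Among the measured compounds shown here, with no comparable step measured, the direction is uncertain; the expected outcome is a modest loss of potency, a step of a 23-fold higher number from compound 2 to compound 3 (1.36 log units; beyond the scatter) that lies beyond the scatter. Compound 3 is therefore estimated at 3 nM, in a range from 0.4 nM to 30 nM.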

Compound 3, half-maximal inhibitory concentration: 7.41 nM
Compound 3: middle estimate off by 2.5-fold (0.39 log units), on the low side, and the stated range covers the measured number.
By their numbers in this assay, from the lowest: compound 2; then compound 3; then compound 1.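

Among these compounds, the change gives a 56-fold higher number from compound 2 to compound 3 (1.75 log units; beyond the scatter) and is the first step here that can be read at a single place. It shows that the group on the saturated chain carbon bound to an oxygen on an aromatic ring strongly affects the number, even with the rest of compound 2 unchanged. No measurement shown explains this loss of potency.

As far as these compounds go, the step swaps both chlorines and adds a fluorine in one move, so the share of each remains open. A 4-chlorophenyl or plain phenyl group at this place would help separate them.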